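A few compounds are considered here, and "the series" means these few. Any claim that something is new, unique, unknown or untested is made for them only; others in the source may bear on it.

Of the compounds shown here, three built on a shared core have been tested in a functional assay on HeLa cells (Homo sapiens) for inhibition, read by MTT assay, with a stated time of 24 h; on this read-out higher numbers stand for weaker inhibition and lower numbers for stronger inhibition. Compound 1 `CCOC(=O)C1=Cc2ccccc2OC1(OCc1cc(-c2ccc(C)cc2)no1)C(F)(F)F` gives only a limit of the assay, > 150000 nM. Compound 2 `CCOC(=O)C1=Cc2ccccc2OC1(OCc1cn(-c2cccc(OC)c2)nn1)C(F)(F)F` likewise gives only a limit, > 150000 nM. Compound 3 `CCOC(=O)C1=Cc2ccccc2OC1(OCc1cc(-c2ccc3ccccc3c2)no1)C(F)(F)F` also gives only a limit, > 150000 nM. Within the data shown here, the single measured step, a step that the two limits leave unreadable from compound 1 to compound 3, cannot be read in size because every value shown sits at the limit of > 150000 nM in this assay, at which 3 of the 3 values shown sit. Compound 2 therefore stands at that limit, with no number of its own.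

Compound 4 `CCOC(=O)C1=Cc2ccccc2OC1(OCc1cn(CC(=O)Nc2ccc(OC)cc2)nn1)C(F)(F)F` has not yet been measured. It differs from compound 2 in one place: ((4-methoxyphenyl)carbamoyl)methyl in place of 3-methoxyphenyl on an aromatic nitrogen. Among the measured compounds shown here, no measured step touches a group on this aromatic nitrogen, and the one measured step has no readable size, so no expected size can be drawn from it. In this assay compound 4 is therefore expected to give 200000 nM, with a range from 100000 nM to 500000 nM, most likely once more as a limit. The step that this estimate means, a step that the limit leaves unreadable from compound 2 to compound 4, is expected to be none beyond the scatter.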

Compound 4, half-maximal inhibitory concentration: 31900 nM
The estimate for compound 4 lay 6.3-fold (0.80 log units) above the measured number; the whole stated range lies above it.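

The group on the aromatic nitrogen of the five-membered ring can change the read-out: in this assay, ((4-methoxyphenyl)carbamoyl)methyl in place of 3-methoxyphenyl gives an at least 4.7-fold lower number from compound 2 to compound 4 (0.67 log units; beyond the scatter) in this pair. Compound 4 is the only compound shown with a number of its own, and the other steps cannot be read: the limit of > 150000 nM in this assay, at which 3 of the 4 values shown sit. The change is also not a single feature, since the entering group has more heavy atoms, a carbonyl, a hydrogen-bond donor that the leaving group lacks, and a methoxy named at 4 rather than 3.

Which of these features carries the step stays open, as does the true size of the step, since compound 2 gives only a limit. Also open, from the compounds shown here alone, is how a carboxylic acid, an amine or a longer chain on this aromatic nitrogen would read in this assay.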